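The compounds below may be only part of what the source reports. "The series", "measured", "known", "first", "only" and "open" are said of these compounds alone.

Measured in a functional assay on HL-60 cells (Homo sapiens) for inhibition, read by MTT assay, with a stated time of 72 h, tested at 50 uM; a lower number here means less inhibition of growth, a higher number more inhibition of growth at the concentration tested:

- compound 1 `C=CCc1ccc(OCc2cn(-c3cccc([N+](=O)[O-])c3)nn2)c(O)c1`: 65.5%
- compound 2 `C=CCc1ccc(OCc2cn(-c3ccc(C#N)cc3)nn2)c(O)c1`: 31.8%
- compound 3 `C=CCc1cc(O)c(O)c(CN2CCC(CO)CC2)c1`: 43.3%

Compound 2, at 31.8%, stands lowest of the three in this assay. Both other compounds lie above it beyond the usual scatter: compound 3 is the nearer at 43.3%, and compound 1 the further at 65.5%.

The next compound to be tested is compound 4 `C=CCc1ccc(OCc2cn(-c3ccc(Br)cc3)nn2)c(O)c1`, which has bromo in place of cyano on an aromatic carbon. For the measured compounds named here, no measured pair isolates this change, so there is no direct precedent for its size. The expectation is a moderate rise in this assay, though a step within the scatter would not be surprising. It is a loose expectation, resting mainly on compound 2 having the lowest value, with compound 1 at 65.5% showing how far the measured compounds reach. The expected change is a number 13.2 percentage points higher from compound 2 to compound 4 (beyond the scatter). For compound 4 the estimated value is 45%, with an expected range from 28% to 65%.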

Compound 4, percent growth inhibition at one concentration: 25.6%
Beside the measured number, compound 4's estimate is 19.4 percentage points above it, outside the stated range (below it).
By their numbers in this assay, from the lowest: compounds 4 and 2 (each within the scatter of the next); then compound 3; then compound 1.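

In this assay, for the compounds shown here, the pair gives the first direct reading of a change on this aromatic carbon, para to a large group: the step is a number 6.2 percentage points lower from compound 2 to compound 4 (within the scatter) and so stays within the usual scatter. Replacing cyano with bromo, which here means one heavy atom in place of two and no hydrogen-bond acceptor in place of one, therefore gives no difference that can be told apart from repeat measurement. No measurement offered here explains this outcome.

The compounds shown leave open whether another group at this place, such as an amine, a carboxylic acid or a longer chain, would shift the number beyond the scatter. They also leave open whether bromo and cyano would read alike on a different core.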